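This account rests on a few compounds, and the source may have more. Where it says the series, first, only, none or still open, it means among the compounds named here.

In an ADME assay on Huh-7 cells (Homo sapiens) for cytotoxicity, read by XTT assay (a lower number here means that less compound is tolerated, a higher number that more compound is tolerated), three compounds have been measured, and none of them gives an exact number. Compound 1 `[N-]=[N+]=N[C@H]1C[C@H](n2cc(Cl)c(=O)[nH]c2=O)O[C@@H]1CO` reads > 100 ug/mL, which is a limit of the assay. Compound 2 `Cc1cn([C@H]2C[C@H](N)[C@@H](CO)O2)c(=O)[nH]c1=O` reads > 100 ug/mL, also a limit. Compound 3 `CCc1cn([C@H]2C[C@H](I)[C@@H](CO)O2)c(=O)[nH]c1=O` reads > 100 ug/mL, again a limit. Compound 3 therefore shares its place with the other two: the limit of > 100 ug/mL in this assay, at which 3 of the 3 values shown sit.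

Compound 4 `CCc1cn([C@H]2C[C@H](F)[C@@H](CO)O2)c(=O)[nH]c1=O` differs from compound 3 by one change, (fluoro in place of iodo on a saturated ring carbon), that is, fluoro in place of iodo on a saturated ring carbon. For the measured compounds named here, no measured step shows what such a swap does here. The expected step of a number no higher from compound 3 to compound 4 (the limit leaves the size open) is none beyond the usual scatter, with no direction favoured. This expectation rests on compound 3, whose limit is > 100 ug/mL. For compound 4 the estimated value is 100 ug/mL, within an expected range of 35 ug/mL to 200 ug/mL.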

Compound 4, half-maximal cytotoxic concentration: > 100 ug/mL
Compound 4: only a limit was reported; the forecaster's own chance of this, stated with the estimate: 80%; the middle value sits exactly at the limit.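

No step can be read from compound 3 to compound 4, since both results are limits and not numbers: the limit of > 100 ug/mL in this assay, at which 4 of the 4 values shown sit.

The compounds shown leave open at what concentration any of them harms these cells, and whether fluoro in place of iodo changes that concentration.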